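The source may hold more compounds than are shown below. What is called first, only, known or untested is meant among the compounds shown, and "the series" means these compounds.

Compound 1 `O=C1C(Nc2ccccc2F)=CC(=O)c2c1nc1n2[C@H]2OC[C@@H](O)[C@H]2OC1`: 9820 nM
Compound 2 `O=C1C(NC2CC2)=CC(=O)c2c1nc1n2[C@H]2OC[C@@H](O)[C@H]2OC1`: > 16000 nM
Compound 3 `COc1cccc(NC2=CC(=O)c3c(nc4n3[C@H]3OC[C@@H](O)[C@H]3OC4)C2=O)c1`: > 8000 nM

These results come from a functional assay on HeLa cells (Homo sapiens) for inhibition, read by sulforhodamine B assay; a higher number here means a weaker inhibitor, a lower number a stronger inhibitor. Only compound 1 has a true number, 9820 nM. Compound 2 is known only by a limit, > 16000 nM. Compound 3 is also known only by a limit, > 8000 nM. From the compounds shown here alone, its relation to the others therefore stays open: a step that the limit leaves unreadable from compound 1 to compound 3, and a step that the two limits leave unreadable from compound 2 to compound 3.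

Compound 4 `O=C1C(NCc2ccccc2)=CC(=O)c2c1nc1n2[C@H]2OC[C@@H](O)[C@H]2OC1` changes one group of compound 3, with benzyl in place of 3-methoxyphenyl on an amine nitrogen. Going by the values given here, the only other change at this nitrogen with any readable size is an at least 1.6-fold higher number from compound 1 to compound 2 (0.21 log units; that floor lies within the scatter). With so little to go on, no clear step in either direction is expected in this assay, and a result reported only as a limit would be unsurprising. The expected change is a step that the limit leaves unreadable from compound 3 to compound 4. For compound 4 the estimated value is 14000 nM, with an expected range from 6000 nM to 30000 nM.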

Compound 4, half-maximal inhibitory concentration: 11000 nM
For compound 4 the middle estimate is 1.3-fold (0.10 log units) above the measured one; low and high end bracket the measured number.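

Going by these compounds alone, compound 4 gives this amine nitrogen its second true number in this assay, so benzyl in place of 2-fluorophenyl is the first change here with a full size: a 1.1-fold higher number from compound 1 to compound 4 (0.05 log units; within the scatter). These two groups therefore cannot be told apart in this measurement, and the other readable step, with benzyl in place of cyclopropyl, is only a floor that supports no order between them: an at least 1.4-fold lower number from compound 2 to compound 4 (0.16 log units; that floor lies within the scatter). The step from compound 3 cannot be read, since compound 3 is known only by a limit: the limit of > 8000 nM in this assay, at which 1 of the 4 values shown sits.

From the compounds shown here alone, it remains open whether any group on this nitrogen can move the number beyond the scatter. A longer chain such as phenethyl, or a chain ending in a carboxylic acid or an amine, would test this.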